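The source may hold more compounds than are shown below. What is called first, only, known or untested is meant among the compounds shown, and "the series" means these compounds.

Compound 3 `Cc1ccc2ncc(S(=O)(=O)c3ccc(Cl)cc3)c(N3CCC(C)CC3)c2c1` carries a 4-chlorophenyl group on a sulfonyl sulfur. In an assay on isolated protein for displacement of a labelled ligand from metabotropic glutamate receptor 5 (Homo sapiens), with a stated time of 60 min, tested at 1 uM (on this read-out lower numbers stand for less inhibition and higher numbers for more inhibition at the one concentration tested (going by the name of the read-out)), compound 3 gives 79%, the lowest of the three numbers recorded. Compound 1 `COc1ccc(S(=O)(=O)c2cnc3ccc(C)cc3c2N2CCC(C)CC2)cc1Cl` gives 93%, and compound 2 `Cc1ccc2ncc(S(=O)(=O)c3ccc(F)c(Cl)c3)c(N3CCC(C)CC3)c2c1` gives 93%; these two lie within the scatter of each other, as the step of no change at the digits printed from compound 1 to compound 2 (within the scatter) shows. Compound 3 stands apart from both: the step of a number 14 percentage points lower from compound 1 to compound 3 (beyond the scatter) and the step of a number 14 percentage points lower from compound 2 to compound 3 (beyond the scatter) are each beyond the scatter, though modest in size. Compound 4 `Cc1ccc2ncc(S(=O)(=O)c3ccc(C#N)cc3)c(N3CCC(C)CC3)c2c1` has not yet been measured. It differs from compound 3 by cyano in place of chloro on an aromatic carbon. Going by the values given here, no measured pair exchanges chloro for cyano, so the two steps into compound 3 bear only indirectly on this change: they show that altering the substitution of the ring on the sulfonyl sulfur moves the read-out by a modest amount. A modest step in either direction is therefore plausible, with no clear ground to expect a rise. Compound 4 is estimated at 72%, with a range from 50% to 90%. This corresponds to an expected step of a number 7 percentage points lower from compound 3 to compound 4 (within the scatter).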

Compound 4, a percentage reported as inhibition, at one concentration (the size of the read-out at that concentration, not a potency): 55%
Compound 4: the middle estimate sits 17 percentage points above what was measured, and the stated range covers the measured number.
By their numbers in this assay, from the lowest: compound 4; then compound 3; then compounds 1 and 2 (each within the scatter of the next).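

With the group on this aromatic carbon, para to a large group, changed from chloro to cyano, this assay shows a step beyond the scatter (a number 24 percentage points lower from compound 3 to compound 4 (beyond the scatter)), whereas fluoro in place of methoxy at the same place had produced none (no change at the digits printed from compound 1 to compound 2 (within the scatter)). The ring on the sulfonyl sulfur can also move the read-out further than the earlier modest steps suggested, since 4-cyanophenyl gives large steps against both 3-chloro-substituted rings (a number 38 percentage points lower from compound 2 to compound 4 (beyond the scatter); a number 38 percentage points lower from compound 1 to compound 4 (beyond the scatter)). No measurement shown here accounts for the effect of the cyano group.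

The compounds shown leave open what an amine or a carboxylic acid would give on this carbon. They also leave open whether a 3-chloro-4-cyanophenyl group would keep the lower number or return towards that of compound 2.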